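Swapping pyrazin-2-yl for 3-methyl-1,2-oxazol-5-yl

The source may report more compounds than this note shows. Statements on the series, on what has been measured and on what is new or still open speak of the compounds shown alone.

Of the compounds shown here, three have so far been measured in a physicochemical assay for lipophilicity, read by HPLC, measured as octanol-water partition, at pH 7.2; on this read-out higher numbers stand for higher lipophilicity and lower numbers for lower lipophilicity. Compound 1 `O=C(Nc1ccc(C(=O)O)cc1)Nc1ccc(F)c(C(F)(F)F)c1` gives 1.5, compound 2 `O=C(Nc1ccc(F)c(C(F)(F)F)c1)Nc1cnccn1` gives 3 and compound 3 `O=C(Nc1ccnc(C(F)(F)F)c1)Nc1ccc(F)c(C(F)(F)F)c1` gives 3.8. Compound 2 therefore stands in the middle of the three, and its gaps to both others lie beyond the usual scatter. Compound 4 `Cc1cc(NC(=O)Nc2ccc(F)c(C(F)(F)F)c2)on1` has not yet been measured. It differs from compound 2 by 3-methyl-1,2-oxazol-5-yl in place of pyrazin-2-yl on an amide-type nitrogen. Among the compounds with values here, no measured pair shows a comparable change, so compound 2 at 3 is the only anchor. A modest upward move is expected, an estimated a number 0.40 log units higher from compound 2 to compound 4 (beyond the scatter), slightly beyond the scatter. Compound 4 is thus expected at 3.4, with an estimated range of 2.9 to 3.9.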

Compound 4, distribution coefficient: 3.2
For compound 4 the middle estimate is 0.20 log units above the measured one; low and high end bracket the measured number.
By their numbers in this assay, from the lowest: compound 1; then compounds 2 and 4 (each within the scatter of the next); then compound 3.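

In this assay, within the data shown here, this is the first pair of compounds that differ in one place, and placing 3-methyl-1,2-oxazol-5-yl in place of pyrazin-2-yl on an amide-type nitrogen gives a number 0.20 log units higher from compound 2 to compound 4 (within the scatter). At this position, then, a five-membered aromatic ring carrying a methyl group and a six-membered aromatic ring read alike in this measurement. Nothing available accounts for this result. As far as these compounds go, whether an ethyl chain or an amine in place of the methyl of 3-methyl-1,2-oxazol-5-yl would leave the reading equally close remains open.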